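The compounds below may be only part of what the source reports. "The series", "measured", "known", "first", "only" and "open" are said of these compounds alone.

The measured compounds:

compound 1 `Cn1nc(C(F)(F)F)cc1C(=O)Nc1ccc(S(=O)(=O)N2CCCCC2)cc1`
compound 2 `Cn1nc(C(F)(F)F)cc1C(=O)Nc1ccc(S(=O)(=O)N2CCC(C(F)(F)F)CC2)cc1`
compound 3 `Cn1nc(C(F)(F)F)cc1C(=O)Nc1ccc(S(=O)(=O)N2CCC(O)CC2)cc1`

In an ADME assay on Vero cells (Chlorocebus sabaeus) for cytotoxicity, read by MTT assay (a higher number here means that more compound is tolerated, a lower number that less compound is tolerated), compound 1 reaches only the limit of the assay, > 300000 nM, and no number is known for it. Compound 2 gives 159000 nM in this assay, and compound 3 gives 274000 nM. Compound 1 therefore sits at the upper edge of what the assay reports (the limit of > 300000 nM in this assay, at which 1 of the 3 values shown sits), and the steps away from it are floors: an at least 1.8-fold lower number from compound 1 to compound 2 (0.27 log units; that floor lies within the scatter), and an at least 1.0-fold lower number from compound 1 to compound 3 (0.03 log units; that floor lies within the scatter).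

Compound 4 `Cn1nc(C(F)(F)F)cc1C(=O)Nc1ccc(S(=O)(=O)N2CCCC(C(=O)O)C2)cc1` is not yet measured. It differs from compound 1 by carboxy in place of hydrogen on a saturated ring carbon. The two measured steps from compound 1, each a substituent entering on a saturated ring carbon of the same ring, bear on this change; both lie within the scatter at their floors, so no step beyond the scatter is expected for compound 4 in this assay either. Compound 4 is accordingly estimated at 250000 nM, with a range of 110000 nM to 400000 nM, which means an expected step of an at least 1.2-fold lower number from compound 1 to compound 4 (0.07 log units; that floor lies within the scatter).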

Compound 4, half-maximal cytotoxic concentration: > 300000 nM
Compound 4: a limit, no number; the forecaster's own chance of this, stated with the estimate: 40%; middle value at least 1.2-fold (0.07 log units) from the limit.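

In this assay compound 4 gives a limit and not a number, so a carboxy group on a saturated ring carbon, two ring bonds from the ring nitrogen, leaves this compound at the same upper edge as compound 1: the limit of > 300000 nM in this assay, at which 2 of the 4 values shown sit. The step between those two compounds cannot be read, as both values are limits. Against the other two substituted compounds the result gives only floors, an at least 1.0-fold higher number from compound 3 to compound 4 (0.03 log units; that floor lies within the scatter) and an at least 1.8-fold higher number from compound 2 to compound 4 (0.27 log units; that floor lies within the scatter), so none of the changes at this ring shows a step beyond the scatter.

As far as these compounds go, whether an amine, a methyl ester or a longer chain ending in a carboxylic acid at this same place would also stay at the limit remains open. The compounds shown also leave open whether trifluoromethyl or hydroxy at this place would give the values seen for compound 2 and compound 3.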